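From isobutoxy to (methylsulfonyl)oxy on the shared core

The source may report more compounds than this note shows. Statements on the series, on what has been measured and on what is new or still open speak of the compounds shown alone.

In a functional assay on P388 cells (Mus musculus) for cytotoxicity (on this read-out lower numbers stand for an effect already at smaller amounts and higher numbers for an effect only at larger amounts of compound), compound 1 `CCOc1cc(-c2ccccc2)nc2ccccc12` gives 6 ug/mL as a true number. Compound 2 `c1ccc(COc2cc(-c3ccccc3)nc3ccccc23)cc1` reports > 10 ug/mL which is a limit. Compound 3 `CC(C)COc1cc(-c2ccccc2)nc2ccccc12` reports > 10 ug/mL which is also a limit. Compound 3 thus rests on the limit of > 10 ug/mL in this assay, at which 2 of the 3 values shown sit, without a number of its own.

Compound 4 `CS(=O)(=O)Oc1cc(-c2ccccc2)nc2ccccc12` carries methylsulfonyl in place of isobutyl on an oxygen on an aromatic ring at the same place. The measured steps all alter the chain on that oxygen. They show an at least 1.6-fold higher number from compound 1 to compound 3 (0.22 log units; that floor lies within the scatter) and an at least 1.6-fold higher number from compound 1 to compound 2 (0.22 log units; that floor lies within the scatter) while the remaining pair gives a step that the two limits leave unreadable from compound 2 to compound 3 as its result. None of them involves a methylsulfonyl group, so they offer only a weak guide, and no step beyond the scatter is expected in either direction. Among the measured compounds shown here, the only true number, from compound 1 at 6 ug/mL as its value, suggests an expected result not far from that number. The expected change is a number no higher from compound 3 to compound 4 (the limit leaves the size open) as far as it can be read. For compound 4 the estimate is 10 ug/mL with an expected range from 3 ug/mL to 30 ug/mL in this assay.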

Compound 4, half-maximal effective concentration: > 10 ug/mL
Compound 4: no number, only a limit; the forecaster's own chance of this, stated with the estimate: 45%; the middle value sits exactly at the limit.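

In this assay, compound 4 has no number of its own, only a limit of the assay at > 10 ug/mL. Among the compounds shown here, the only readable step is an at least 1.6-fold higher number from compound 1 to compound 4 (0.22 log units; that floor lies within the scatter), while the steps from compound 2 and compound 3 to compound 4 cannot be read. Methylsulfonyl is the first group on this oxygen that is not a carbon chain, bringing a sulfur and hydrogen-bond acceptors, yet the result stays at the same ceiling: the limit of > 10 ug/mL in this assay, at which 3 of the 4 values shown sit.

Going by these compounds, how far compound 2, compound 3 and compound 4 lie beyond that limit stays open, so the read-out cannot rank benzyl, isobutyl and methylsulfonyl against one another. On these data alone, it also stays open whether a methyl group, or a chain ending in an amine or a carboxylic acid, on this oxygen would give a number lower than that of compound 1.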